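Permeability notes: replacing the carboxypiperidinyl of compound 3 with dimethylamino

The source may hold more compounds than are shown below. What is called first, only, known or untested is meant among the compounds shown, and "the series" means these compounds.

The series shares an amide-linked core, seen in compound 1 `Cc1ccc(-c2nc3ccccc3s2)cc1NC(=O)c1cc([N+](=O)[O-])c(N2CCCCC2)cc1Cl`, compound 2 `O=C(Nc1cccc(-c2nc3ccccc3s2)c1)c1cc([N+](=O)[O-])ccc1Cl` and compound 3 `Cc1ccc(-c2nc3ccccc3s2)cc1NC(=O)c1cc([N+](=O)[O-])c(N2CCC(C(=O)O)CC2)cc1Cl`. In an ADME assay for permeability, using PAMPA, at pH 7.4 (a lower number here means that the compound crosses the layer more slowly, a higher number that the compound crosses the layer faster), compound 3 gives 17 10^-6 cm/s. Compound 2 gives 12 10^-6 cm/s, which sits within the scatter of compound 3, so the two are not ordered. Compound 1 is reported only as a limit, < 1 10^-6 cm/s, not as a number; this is the limit of < 1 10^-6 cm/s in this assay, at which 1 of the 3 values shown sits.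

Among the compounds with values here, the one step measured here that varies the amine on the aromatic ring of the core is an at least 17-fold higher number from compound 1 to compound 3 (1.23 log units; beyond the scatter). That step adds a carboxy to the saturated ring, and its size is set by the limit at which compound 1 sits.

Compound 4 `Cc1ccc(-c2nc3ccccc3s2)cc1NC(=O)c1cc([N+](=O)[O-])c(N(C)C)cc1Cl` differs from compound 3 in that (dimethylamino in place of 4-carboxypiperidin-1-yl on an aromatic carbon). Compound 4 thus carries neither the carboxy nor the saturated ring, and in this respect it resembles compound 1 more than compound 3. The step from compound 1 to compound 3 therefore bears on it, in reverse, and a large drop in this assay is expected, an 8.5-fold lower number from compound 3 to compound 4 (0.93 log units; beyond the scatter), with a real chance of a limit rather than a number. Compound 4 is estimated at 2 10^-6 cm/s, ranging from 0.7 10^-6 cm/s to 8 10^-6 cm/s.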

Compound 4, apparent permeability in the ADME assay: < 1 10^-6 cm/s
Compound 4 ended at the assay's limit; the forecaster's own chance of this, stated with the estimate: 30%; at least 2.0-fold (0.30 log units) between middle value and limit.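

At this aromatic carbon, ortho to a nitro group, the change gives in the ADME assay an at least 17-fold lower number from compound 3 to compound 4 (1.23 log units; beyond the scatter). Dimethylamino and piperidin-1-yl both end at a limit of the assay, not at a number, so among these three amines only 4-carboxypiperidin-1-yl gives a number, and the step between compound 1 and compound 4 cannot be read since both values are limits: the limit of < 1 10^-6 cm/s in the ADME assay, at which 2 of the 4 values shown sit.

In a physicochemical assay for solubility, read by spectrophotometry, in phosphate buffer, measured as kinetic solubility, with a stated time of 18 h, at pH 7.4 (on this read-out lower numbers stand for lower solubility and higher numbers for higher solubility), compound 3 gives 590 nM and compound 4 gives 30 nM, so the same change also comes with lower solubility: the measured solubility of compound 3, 590 nM, and of compound 4, 30 nM, a 20-fold lower number (1.29 log units; beyond the scatter)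

Whether the number seen with compound 3 depends on the carboxy standing on a saturated ring stays open, as a carboxylic acid on an open chain at this aromatic carbon is not among the compounds shown. Also open, going by these compounds, is whether a hydroxy group or a primary amide in place of the carboxy on the piperidine ring would give a number or end at the same limit.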